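From chloro to dimethylamino on the shared core

The source may report more compounds than this note shows. Statements on the series, on what has been measured and on what is new or still open speak of the compounds shown alone.

In an ADME assay on HPLF cells (Homo sapiens) for cytotoxicity, with a stated time of 24 h (a higher number here means that more compound is tolerated, a lower number that less compound is tolerated), compound 1 (`O=C1/C(=C/c2ccc(F)cc2)CCC/C1=C\c1cccc([N+](=O)[O-])c1`) gives 36000 nM and compound 2 (`O=C1/C(=C/c2ccc(Cl)cc2)CCC/C1=C\c1cccc([N+](=O)[O-])c1`) gives 38000 nM so these two numbers stand within the scatter of each other. Compound 3 (`CN(C)c1ccc(/C=C2\CCC/C(=C\c3cccc([N+](=O)[O-])c3)C2=O)cc1`) has dimethylamino in place of chloro on an aromatic carbon, para to a large group (dimethylamino in place of chloro on an aromatic carbon). Going by the values given here, the only measured step that bears on this change is a 1.1-fold higher number from compound 1 to compound 2 (0.02 log units; within the scatter) with chloro in place of fluoro on an aromatic carbon, and it lies within the scatter. Among the compounds with values here, no measured compound yet carries dimethylamino, so that step offers only weak guidance and fixes no direction. No step beyond the scatter is therefore expected in this assay although the range is kept wide. The estimated step is a 1.3-fold lower number from compound 2 to compound 3 (0.10 log units; within the scatter) on this reasoning. Compound 3 is expected at 30000 nM with an estimated range from 10000 nM to 80000 nM in this assay.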

Compound 3, half-maximal cytotoxic concentration: > 400000 nM
Compound 3 was reported as a limit (the forecaster's own chance of this, stated with the estimate: 10%); at least 13-fold (1.12 log units) between middle value and limit.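

In this assay, the earlier exchange between two halogens at this position left the number within the scatter, whereas a change on the same aromatic carbon, para to a large group, now gives a large step. Dimethylamino in place of chloro gives an at least 10-fold higher number from compound 2 to compound 3 (1.02 log units; beyond the scatter), and dimethylamino in place of fluoro gives an at least 11-fold higher number from compound 1 to compound 3 (1.04 log units; beyond the scatter). The value of compound 3 is a limit and not a number, so these steps have a lower bound only: the limit of > 400000 nM in this assay, at which 1 of the 3 values shown sits.

How far the true value of compound 3 lies past that limit remains open, as does the cause of the step. As far as these compounds go, whether a smaller amine such as methylamino or an oxygen group such as methoxy at this position would give a similar step also remains open.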